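Working notes: fluoro to chloro exchange on the aryl ring

The source may hold more compounds than are shown below. What is called first, only, known or untested is meant among the compounds shown, and "the series" means these compounds.

Compound 1 `Cc1ccc(-c2n[nH]c3c2CCNCC3)cc1` carries a methyl on the aromatic carbon; in an assay on cells for displacement of a labelled ligand from 5-hydroxytryptamine receptor 3A (Homo sapiens), read by scintillation counting, with a stated time of 1.5 h (a lower number here means a stronger inhibitor, a higher number a weaker inhibitor), compound 1 gives > 10000 nM, which is a limit of the assay rather than a number. Compound 2 `Fc1ccc(-c2n[nH]c3c2CCNCC3)cc1` carries fluoro in place of that methyl. In this assay compound 2 gives > 10000 nM, again a limit and not a number. The step that the two limits leave unreadable from compound 1 to compound 2 cannot be read in size, since both values sit at the limit of > 10000 nM in this assay, at which 2 of the 2 values shown sit. Going by the values given here, compound 2 therefore stands at the assay limit, as does the only other value measured so far. Compound 3 `Clc1ccc(-c2n[nH]c3c2CCNCC3)cc1` differs from compound 2 by chloro in place of fluoro on an aromatic carbon. Among the compounds with values here, the one measured step concerns the same aromatic carbon and is unreadable, so it gives no direction; with both measured compounds at the limit, compound 3 is expected to remain there as well. The expected step that the limit leaves unreadable from compound 2 to compound 3 is essentially none. Compound 3 is estimated at 15000 nM, with a range from 5000 nM to 50000 nM.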

Compound 3, inhibition constant: > 10000 nM
Compound 3: a limit, no number; the forecaster's own chance of this, stated with the estimate: 80%; the middle value lies beyond the limit too.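

No step among compound 1, compound 2 and compound 3 can be read, as all three give only a limit of the assay: the limit of > 10000 nM in this assay, at which 3 of the 3 values shown sit.

The compounds shown leave open whether methyl, fluoro and chloro on this aromatic carbon differ at all in this assay.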